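Flipping Two Stereocentres of Compound 2

This account rests on a few compounds, and the source may have more. Where it says the series, first, only, none or still open, it means among the compounds named here.

In an ADME assay on Akata cells (Homo sapiens) for cytotoxicity (on this read-out lower numbers stand for higher toxicity in this test and higher numbers for lower toxicity in this test), compound 1 `Nc1nc2c(ncn2/C=C2\C[C@@H]2[C@@H](O)CO)c(=O)[nH]1` gives 61000 nM and compound 2 `Nc1nc2c(ncn2/C=C2/C[C@@H]2[C@@H](O)CO)c(=O)[nH]1` gives 56000 nM. These two numbers lie within the usual scatter of each other, so compound 2 stands level with compound 1. Compound 3 `Nc1nc2c(ncn2/C=C2/C[C@H]2[C@H](O)CO)c(=O)[nH]1` departs from compound 2 as follows: the two compounds have the same atoms and bonds and differ only in configuration as drawn: 2 of 3 stereo elements differ; a stereocentre at a saturated ring carbon is drawn S in compound 2 and R in compound 3; a stereocentre at a saturated chain carbon is drawn R in compound 2 and S in compound 3. Thus a stereocentre at a saturated ring carbon and a stereocentre at a saturated chain carbon both change, while the double bond stays as drawn. For the measured compounds named here, only one measured step bears on this: a 1.1-fold lower number from compound 1 to compound 2 (0.04 log units; within the scatter), within the scatter. It is a comparison of the same kind, resting on (the fact that compounds 1 and 2 differ only in the configuration as drawn), although it concerns the double bond and not these stereocentres. No step beyond the scatter is therefore expected in this assay, and the expected change is a 1.1-fold higher number from compound 2 to compound 3 (0.03 log units; within the scatter). Compound 3 is estimated at 60000 nM, with an expected range of 28000 nM to 120000 nM.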

Compound 3, half-maximal cytotoxic concentration: 62600 nM
Estimate against measurement, compound 3: 1.0-fold (0.02 log units) below; the range from low to high includes it.
By their numbers in this assay, from the lowest: compounds 2, 1 and 3 (each within the scatter of the next).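

In this assay, changing both stereocentres together gives a 1.1-fold higher number from compound 2 to compound 3 (0.05 log units; within the scatter), so the lack of a readable difference seen earlier for the double bond now also holds for this paired change at the saturated ring carbon and the saturated chain carbon. Changing all three stereo elements gives a 1.0-fold higher number from compound 1 to compound 3 (0.01 log units; within the scatter), so none of the three drawn arrangements stands apart in this test. These comparisons isolate configuration, with no atoms or bonds altered: the fact that compounds 2 and 3 differ only in the configuration as drawn

On these data alone, the two stereocentres appear here only as a pair, so the result of changing either one alone stays open, as does the possibility that two opposing effects cancel. As far as these compounds go, it is also open whether the same lack of difference would hold with an amine or a carboxylic acid in place of a hydroxyl group on the side chain.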